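From methoxymethyl to dimethylcarbamoyl on compound 3

The compounds below may be only part of what the source reports. "The series", "measured", "known", "first", "only" and "open" are said of these compounds alone.

Of the compounds shown here, three with a shared core have been measured in a physicochemical assay for solubility, in phosphate buffer, at pH 6.8; a lower number here means a less soluble compound, a higher number a more soluble compound. Compound 1 (`CC(C)(C)C(=O)C1=C(O)C(=O)N(c2ccc(-c3ccsc3)cc2)C1c1ccccc1OCCO`) reads > 50000 nM, which is a limit of the assay and not a number. Compound 2 (`CC(C)(C)C(=O)C1=C(O)C(=O)N(c2ccc(-c3cccs3)cc2)C1c1ccccc1OCCO`) gives 38600 nM. Among the measured compounds shown here, compound 3 (`COCCOc1ccccc1C1C(C(=O)C(C)(C)C)=C(O)C(=O)N1c1ccc(-c2ccsc2)cc1`) gives 22800 nM, and this value lies within the usual scatter of the one for compound 2.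

The next compound changes the chain of compound 3. Compound 4 (`CN(C)C(=O)COc1ccccc1C1C(C(=O)C(C)(C)C)=C(O)C(=O)N1c1ccc(-c2ccsc2)cc1`) has dimethylcarbamoyl in place of methoxymethyl on a saturated chain carbon bound to an oxygen on an aromatic ring.

For the measured compounds named here, no measured step makes this exact swap. The closest one alters the same chain, placing methyl in place of hydrogen on an oxygen on a saturated carbon, and gives an at least 2.1-fold lower number from compound 1 to compound 3 (0.34 log units; beyond the scatter). The other step, thiophen-2-yl in place of thiophen-3-yl on an aromatic carbon, changes a different place and gives an at least 1.2-fold lower number from compound 1 to compound 2 (0.11 log units; that floor lies within the scatter), so it says little here. Both steps start from a limit, so each gives only a floor on its size.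

With so little to go on, no shift beyond the scatter is expected, and the expected step is a 1.1-fold lower number from compound 3 to compound 4 (0.06 log units; within the scatter). For compound 4 the estimate is 20000 nM, with an expected range from 7000 nM to 50000 nM.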

Compound 4, solubility: > 50000 nM
Compound 4 was reported as a limit; the forecaster's own chance of this, stated with the estimate: 10%; middle value at least 2.5-fold (0.39 log units) from the limit.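

In this assay, dimethylcarbamoyl in place of methoxymethyl, on a saturated chain carbon bound to an oxygen on an aromatic ring, gives an at least 2.1-fold higher number from compound 3 to compound 4 (0.34 log units; beyond the scatter). Compound 4 reads > 50000 nM, which is a limit of the assay and not a number, so the true size of this step may be larger than its printed floor. The earlier change on this chain went the other way, with an at least 2.1-fold lower number from compound 1 to compound 3 (0.34 log units; beyond the scatter), so the two steps together show that changes to this chain can move the read-out in either direction, which compound 3 alone could not show.

Going by these compounds, compound 1 and compound 4 cannot be ranked against each other, and their step cannot be read, because both sit at the same limit: the limit of > 50000 nM in this assay, at which 2 of the 4 values shown sit. Still open is how an amine, a carboxylic acid or a longer chain in this same place would read in this assay, and whether dimethylcarbamoyl would give a similar step alongside the thiophen-2-yl group of compound 2.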